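Swapping the Carboxyphenyl for a Hydroxyalkyl Chain

This account rests on a few compounds, and the source may have more. Where it says the series, first, only, none or still open, it means among the compounds named here.

For the measured compounds named here, compound 2 `O=C(O)c1ccc(N2CCC(NS(=O)(=O)c3cc(S(=O)(=O)c4ccccc4)ccc3C(F)(F)F)CC2)cc1` is one of two compounds measured in an assay on U2OS cells for inhibition of secreted frizzled-related protein 1 (Homo sapiens), read by a luciferase reporter, with a stated time of 18 h (a lower number here means that less compound is needed, a higher number that more compound is needed for the effect), where compound 2 gives 230 nM. Going by the values given here, its only measured neighbour is compound 1 `O=C(c1ccc(Cl)nc1)N1CCC(NS(=O)(=O)c2cc(S(=O)(=O)c3ccccc3)ccc2C(F)(F)F)CC1`, which gives 140 nM; the step of a 1.6-fold higher number from compound 1 to compound 2 (0.22 log units; within the scatter) sits within the scatter, so the two compounds cannot be told apart on these numbers. Compound 3 `CC(C)(O)CCN1CCC(NS(=O)(=O)c2cc(S(=O)(=O)c3ccccc3)ccc2C(F)(F)F)CC1` has not yet been measured. It differs from compound 2 only at the amine nitrogen in the ring: 3-hydroxy-3-methylbutyl in place of 4-carboxyphenyl on an amine nitrogen in a ring. Among the compounds with values here, no measured step covers this particular exchange. Within the data shown here, the one step available, a 1.6-fold higher number from compound 1 to compound 2 (0.22 log units; within the scatter), also swaps a group on that same nitrogen and stays within the scatter. On that slender basis the expected step from compound 2 is a 1.1-fold higher number from compound 2 to compound 3 (0.04 log units; within the scatter), that is, no change beyond the scatter. Compound 3 is therefore estimated at 250 nM, within a range from 100 nM to 650 nM.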

Compound 3, half-maximal effective concentration: 630 nM
Compound 3: middle estimate off by 2.5-fold (0.40 log units), on the low side; measured number inside the range.
By their numbers in this assay, from the lowest: compounds 1 and 2 (each within the scatter of the next); then compound 3.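

The amine nitrogen in the six-membered ring is not indifferent to what it carries: the earlier exchange there stayed within the scatter, but in this assay placing 3-hydroxy-3-methylbutyl on it gives a 2.7-fold higher number from compound 2 to compound 3 (0.44 log units; beyond the scatter). The same group, compared with the other earlier compound, gives a 4.5-fold higher number from compound 1 to compound 3 (0.65 log units; beyond the scatter), so among these three compounds the open chain needs more compound than either group that contains a ring. No measurement available here bears on why the number rises.

Going by these compounds, it remains open whether the loss of the ring or the nature of the chain matters more: a benzyl group or a plain 3-methylbutyl chain on the same nitrogen would help separate the two. A longer chain ending in a carboxylic acid would test whether the acid can stand in a chain without the aromatic ring.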